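The compounds below may be only part of what the source reports. "The series", "measured", "known", "first", "only" and "open" are said of these compounds alone.

Measured compounds in an ADME assay on HEK-293T cells (Homo sapiens) for cytotoxicity, read by MTT assay, with a stated time of 24 h; a lower number here means that less compound is tolerated, a higher number that more compound is tolerated:
compound 1 `Cc1ccc(-c2nn(-c3ccccc3)cc2-c2nc3ccccc3n2C(=O)c2ccccc2C)cc1`, compound 1 gives 176000 nM;
compound 2 `Cc1ccccc1C(=O)n1c(-c2cn(-c3ccccc3)nc2-c2ccc(F)cc2)nc2ccccc21`, compound 2 gives 189000 nM;
compound 3 `Cc1cccc(C(=O)n2c(-c3cn(-c4ccccc4)nc3-c3ccc(C(F)(F)F)cc3)nc3ccccc32)c1`, compound 3 gives 154000 nM.

Compound 2 holds the highest of the three numbers in this assay, but the gaps to compound 1 and to compound 3 are both within the scatter, so the three compounds cannot be ordered on these data. Going by the values given here, the only measured step that differs in one place is a 1.1-fold higher number from compound 1 to compound 2 (0.03 log units; within the scatter).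

Compound 4 `Cc1ccc(C(=O)n2c(-c3cn(-c4ccccc4)nc3-c3ccc(F)cc3)nc3ccccc32)cn1` differs from compound 2 as follows: 6-methylpyridin-3-yl in place of 2-methylphenyl on a carbonyl carbon. Among the compounds with values here, this change is at a different place from the one step measured, so no step bears on it directly. All three measured compounds sit within the scatter of one another regardless of which group is on the carbonyl carbon or on the aromatic carbon, and nothing among them points to a shift in this assay beyond the scatter in either direction. The expected step is therefore a 1.1-fold lower number from compound 2 to compound 4 (0.02 log units; within the scatter). Compound 4 is estimated at 180000 nM in this assay, with a range from 90000 nM to 360000 nM.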

Compound 4, half-maximal cytotoxic concentration: 137000 nM
Compound 4: middle estimate off by 1.3-fold (0.12 log units), on the high side, and the stated range covers the measured number.
By their numbers in this assay, from the lowest: compounds 4, 3, 1 and 2 (each within the scatter of the next).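

Going by these compounds alone, this is the first measured step at the carbonyl carbon, as the only earlier step concerned a different place. In this assay, 6-methylpyridin-3-yl in place of 2-methylphenyl gives a 1.4-fold lower number from compound 2 to compound 4 (0.14 log units; within the scatter), so bringing a ring nitrogen and a hydrogen-bond acceptor into this group leaves the number within the scatter. No supporting data bear on this result.

As far as these compounds go, it remains open whether an amine or a carboxylic acid on the group at the carbonyl carbon would take the number beyond the scatter in this assay. Also open, from the compounds shown here alone, is whether the same exchange of groups would read alike in the settings of compound 1 and compound 3, which carry methyl and trifluoromethyl where compound 2 carries fluoro.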